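The compounds below may be only part of what the source reports. "The series", "measured", "known", "first", "only" and "open" are said of these compounds alone.

Working notes on the series, antiproliferative read-out.

Compound 1 `N#CC1=C(N)Oc2c(c3nc4ccccc4nc3c3ccccc23)C12C(=O)N(Cc1cnnn1-c1ccc(S(N)(=O)=O)cc1)c1ccccc12` in a functional assay on HepG2 cells (Homo sapiens) for antiproliferative activity, read by MTT assay, with a stated time of 48 h (on this read-out higher numbers stand for weaker inhibition and lower numbers for stronger inhibition), gives 42200 nM. Compound 2 `Cc1ccc(C)c(-n2nncc2CN2C(=O)C3(C(C#N)=C(N)Oc4c3c3nc5ccccc5nc3c3ccccc43)c3ccccc32)c1` in this assay gives > 50000 nM, which is a limit of the assay and not a number. The step of an at least 1.1-fold higher number from compound 1 to compound 2 (0.07 log units; that floor lies within the scatter) is accordingly known only as a floor, and that floor lies within the scatter.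

Compound 3 `N#CC1=C(N)Oc2c(N)cc3nc4ccccc4nc3c2C12C(=O)N(Cc1cnnn1-c1cccc(Br)c1)c1ccccc12` in this assay gives > 50000 nM, again a limit of the assay and not a number. On the numbers shown, compound 3 stands at the edge of what the assay reports, sharing the limit of > 50000 nM in this assay, at which 2 of the 3 values shown sit, with compound 2; no ordering against the others is possible.

Compound 4 `CCOc1ccccc1-n1nncc1CN1C(=O)C2(C(C#N)=C(N)Oc3c(N)cc4nc5ccccc5nc4c32)c2ccccc21` is not yet measured in this assay. It differs from compound 3 by 2-ethoxyphenyl in place of 3-bromophenyl on an aromatic nitrogen. Going by the values given here, the only measured step that touches the same place, from compound 1 to compound 2, is a floor within the scatter, so it gives no direction for this change. No step beyond the scatter is therefore expected in this assay, and a further limit is the most likely outcome.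

Compound 4 is thus expected to give about 60000 nM, within 20000 nM to 180000 nM. The expected step from compound 3 to compound 4 is a step that the limit leaves unreadable from compound 3 to compound 4.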

Compound 4, half-maximal inhibitory concentration: 30500 nM
Compound 4: the middle estimate sits 2.0-fold (0.29 log units) above what was measured; the measured number falls inside the stated range.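

Going by these compounds alone, on the core of compound 3, 2-ethoxyphenyl on the aromatic nitrogen gives the first actual number for that core in this assay, with compound 4 at 30500 nM. The change reads as an at least 1.6-fold lower number from compound 3 to compound 4 (0.21 log units; that floor lies within the scatter), so this position can now be said to allow a measurable read-out on this core, but neither the direction nor the true size of the change is settled. The step can be no more than a floor because compound 3 is a limit of the assay and not a number: the limit of > 50000 nM in this assay, at which 2 of the 4 values shown sit.

The compounds shown leave open whether the number for compound 4 comes from the ethoxy group itself or from the position it holds on the phenyl ring, since 3-bromophenyl is the only comparison on this core and it ends at a limit. Also open, on these data alone, is how a methoxy group, a longer alkoxy chain, an amine or a carboxylic acid on that phenyl ring would read on the same core, and whether any of these would give a step beyond the scatter.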